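A few compounds are considered here, and "the series" means these few. Any claim that something is new, unique, unknown or untested is made for them only; others in the source may bear on it.

Three thiosemicarbazones of a shared core were measured for lipophilicity in a physicochemical assay for lipophilicity, in phosphate buffer, measured as octanol-water partition, with a stated time of 24 h; a higher number here means a more lipophilic compound, a lower number a more polar compound. For the measured compounds named here, compound 1 `S=C(N/N=C/c1ccc(Oc2ccc(Cl)cc2)cc1)Nc1ccccc1` gives 5.52, and compound 2 `S=C(N/N=C/c1ccc(Oc2ccc(Cl)cc2)cc1)Nc1ccc(Br)cc1` gives 6.24; the step of a number 0.72 log units higher from compound 1 to compound 2 (beyond the scatter) is the only change measured so far at one place. Compound 3 `S=C(N/N=C/c1ccc(Oc2ccc3ccccc3c2)cc1)Nc1ccc(Cl)cc1` gives 6.96 in this assay, the highest of the three numbers: it stands above compound 2 and further above compound 1, both gaps beyond the scatter.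

Compound 4 `Cc1ccc(Oc2ccc(/C=N/NC(=S)Nc3ccc(Cl)cc3)cc2)cc1` has not yet been measured. It differs from compound 3 by 4-methylphenyl in place of naphthalen-2-yl on an oxygen on an aromatic ring. Going by the values given here, none of the measured steps touches this position, so the single step from compound 1 to compound 2 bears on it only as a sign of how far a one-place change has moved this assay here. Because compound 3 stands at 6.96 and the change removes one of the two carbon rings of the naphthalen-2-yl group while adding a methyl, the number for compound 4 is expected to fall by a number 0.66 log units lower from compound 3 to compound 4 (beyond the scatter). Compound 4 is therefore estimated at 6.3, in a range from 5.8 to 6.8.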

Compound 4, partition coefficient: 5.97
Compound 4: the middle estimate sits 0.33 log units above what was measured, and the stated range covers the measured number.
By their numbers in this assay, from the lowest: compound 1; then compounds 4 and 2 (each within the scatter of the next); then compound 3.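

In this assay, 4-methylphenyl in place of naphthalen-2-yl on an oxygen on an aromatic ring gives a number 0.99 log units lower from compound 3 to compound 4 (beyond the scatter), the first measured sign that the number responds to the group at this position. The step replaces a group with 2 six-membered aromatic rings of carbon only and 10 heavy atoms by one with a single such ring and 7 heavy atoms, so the loss of a ring and the presence of the methyl are read together and cannot be separated here. Nothing measured on these compounds accounts for the size of this step.

The compounds shown leave open how a plain phenyl, or a ring bearing an amine or a carboxylic acid, would stand at this position, and what a longer chain in place of the methyl would do. They also leave open whether this step would keep its size in a compound carrying bromo, as compound 2 does.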